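This account rests on a few compounds, and the source may have more. Where it says the series, first, only, none or still open, it means among the compounds named here.

Working notes on the series.

All numbers below come from a functional assay on BT-549 cells (Homo sapiens) for inhibition, read by sulforhodamine B assay, with a stated time of 48 h; on this read-out lower numbers stand for stronger inhibition of growth and higher numbers for weaker inhibition of growth.

- compound 1, `COc1ccc(-c2cc(/C=C/C(=O)c3ccc(N)cc3)[nH]n2)cc1`, gives 1740 nM
- compound 2, `COc1ccc(C(=O)/C=C/c2cc(-c3cc(OC)c(OC)c(OC)c3)n[nH]2)cc1OC`, gives 1440 nM
- compound 3, `COc1ccc(-c2cc(/C=C/C(=O)c3ccc(N)cc3)[nH]n2)cc1OC`, gives 1500 nM

The three measured values sit close together; none of the gaps between them is large enough to separate the compounds. Compound 1 and compound 3 share one core, compound 2 is built on a different one, and the difference between the two cores is not broken down here.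

Among the compounds with values here, the one change that is measured is methoxy in place of hydrogen on an aromatic carbon. Its step, a 1.2-fold lower number from compound 1 to compound 3 (0.06 log units; within the scatter), is small.

Still to be measured is compound 4, `COc1cc(C(=O)/C=C/c2cc(-c3cc(OC)c(OC)c(OC)c3)n[nH]2)cc(OC)c1OC`. It arises from compound 2 by methoxy in place of hydrogen on an aromatic carbon. Within the data shown here, this is the same kind of change as the one from compound 1 to compound 3, but the place is not identical: in compound 4 the new methoxy group is also meta to a methoxy group, which is not the case in compound 3. The expectation therefore rests on a single measured step made on a different core.

Among the measured compounds shown here, the expected step in this assay is a 1.1-fold lower number from compound 2 to compound 4 (0.04 log units; within the scatter), which is set beside a 1.2-fold lower number from compound 1 to compound 3 (0.06 log units; within the scatter) and taken as small for the same reason: the one measured example of this change moved the number only a little. Compound 4 is thus expected to give about 1300 nM, with a plausible span from 600 nM to 2800 nM, and no reason from the data to expect a large shift in either direction.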

Compound 4, concentration for 50% growth inhibition: 1570 nM
Compound 4: middle estimate off by 1.2-fold (0.08 log units), on the low side; measured number inside the range.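

In this assay, methoxy in place of hydrogen on an aromatic carbon now has a second measured step, a 1.1-fold higher number from compound 2 to compound 4 (0.04 log units; within the scatter), and the two steps cannot be told apart: the same change on two cores in this assay, a 1.2-fold lower number (0.06 log units; within the scatter) from compound 1 to compound 3 and a 1.1-fold higher number (0.04 log units; within the scatter) from compound 2 to compound 4, 1.3-fold (0.10 log units) apart, within the scatter of two such steps.

For these two pairs, the change carries from one core to the other without a measurable shift in growth inhibition, and the opposite directions of the two steps carry no meaning at this size. Within the data shown here, this does not show that methoxy is without consequence at every position or on every core, since there are only two examples, the places differ, and in compound 4 the new group is ortho to a methoxy group and also meta to a methoxy group.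

The compounds shown leave open whether a hydroxyl group, a fluorine atom, a carboxylic acid or a longer chain such as ethoxy at this place would move the number beyond the scatter, since methoxy is the only group exchanged for hydrogen here. Among these compounds, they also leave open how much the core itself contributes, as no pair among them differs in the core alone.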